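A few compounds are considered here, and "the series" means these few. Any claim that something is new, unique, unknown or untested is made for them only; others in the source may bear on it.

Working notes on the series. Three compounds share one core and differ only in the aromatic group attached to the six-membered ring. Compound 1 `c1ccc(-c2cccc3c2CCC3c2ncc[nH]2)nc1` gives 1150 nM in a functional assay on CHO cells for agonist activity at Alpha-1A adrenergic receptor (Homo sapiens), read by FLIPR and calcium flux; on this read-out lower numbers stand for an effect already at smaller amounts and higher numbers for an effect only at larger amounts of compound. Compound 2 `c1cncc(-c2cccc3c2CCC3c2ncc[nH]2)c1` gives 2060 nM; the step of a 1.8-fold higher number from compound 1 to compound 2 (0.25 log units; within the scatter) does not separate the two. Among the measured compounds shown here, compound 3 `Cc1oncc1-c1cccc2c1CCC2c1ncc[nH]1` gives 111 nM, the lowest number of the three and beyond the scatter from both others, so compound 3 is the most potent compound measured so far; the steps of a 10-fold lower number from compound 1 to compound 3 (1.02 log units; beyond the scatter) and a 19-fold lower number from compound 2 to compound 3 (1.27 log units; beyond the scatter) show that the five-membered 5-methyl-1,2-oxazol-4-yl is strongly favoured over either pyridyl.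

Compound 4 `c1cc(-c2nccs2)c2c(c1)C(c1ncc[nH]1)CC2` is not yet measured. Compared with compound 3 it carries 1,3-thiazol-2-yl in place of 5-methyl-1,2-oxazol-4-yl on an aromatic carbon. For the measured compounds named here, no measured step exchanges one five-membered aromatic ring for another; the only steps that bear on this place are the two large gains from the pyridyls to the oxazole, and the neutral swap between the two pyridyls. The change keeps a five-membered ring with two hetero atoms but loses the methyl and alters the attachment. The expectation is therefore a number somewhat higher than compound 3, the step of a 2.7-fold higher number from compound 3 to compound 4 (0.43 log units; beyond the scatter) being expected to fall between the oxazole and the pyridyls. Compound 4 is estimated at 300 nM, with a range from 80 nM to 1200 nM.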

Compound 4, half-maximal effective concentration: 426 nM
Beside the measured number, compound 4's estimate is 1.4-fold (0.15 log units) below it; the measured number falls inside the stated range.
By their numbers in this assay, from the lowest: compound 3; then compound 4; then compounds 1 and 2 (each within the scatter of the next).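

In this assay, among the compounds shown here, this is the first exchange of one five-membered aromatic ring for another on this aromatic carbon, and the ring type alone does not fix the number: 1,3-thiazol-2-yl in place of 5-methyl-1,2-oxazol-4-yl gives a step beyond the scatter (a 3.8-fold higher number from compound 3 to compound 4 (0.58 log units; beyond the scatter)). The 1,3-thiazol-2-yl nevertheless keeps an advantage over both pyridyls (a 4.8-fold lower number from compound 2 to compound 4 (0.68 log units; beyond the scatter) and a 2.7-fold lower number from compound 1 to compound 4 (0.43 log units; beyond the scatter)), so among these four compounds both five-membered rings give lower numbers than both pyridyls, with no compound against that pattern, and the two five-membered rings are themselves separated. No measurement shown here accounts for the difference between the two five-membered rings.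

The step from compound 3 to compound 4 changes the ring hetero atoms, the attachment and the methyl together, so the contribution of each stays unresolved. An unsubstituted 1,2-oxazol-4-yl or a methyl-bearing 1,3-thiazol-2-yl would separate these contributions, while an open-chain group such as an amine or a carboxylic acid at this place remains an open question.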